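This account rests on a few compounds, and the source may have more. Where it says the series, first, only, none or still open, it means among the compounds named here.

Compound 1 `CC1(C)[C@H]2CC[C@]1(C)N(Cc1cn(-c3ccc(Cl)cc3)nn1)C(=O)C2` is the reference point for this comparison. In a functional assay on SGC-7901 cells (Homo sapiens) for inhibition, read by MTT assay, with a stated time of 24 h (on this read-out lower numbers stand for stronger inhibition and higher numbers for weaker inhibition), compound 1 gives 410 nM, the highest of the three numbers measured. Compound 2 `CC1(C)[C@H]2CC[C@]1(C)N(Cc1cn(-c3cccc(O)c3)nn1)C(=O)C2` gives 270 nM, and compound 3 `CC1(C)[C@H]2CC[C@]1(C)N(Cc1cn(-c3ccccc3Cl)nn1)C(=O)C2` gives 220 nM. The steps away from compound 1 were small: a 1.5-fold lower number from compound 1 to compound 2 (0.18 log units; within the scatter) and a 1.9-fold lower number from compound 1 to compound 3 (0.27 log units; within the scatter), neither beyond the scatter. Compound 4 `CC1(C)[C@H]2CC[C@]1(C)N(Cc1cn(-c3ccccc3F)nn1)C(=O)C2` is not yet measured; it differs from compound 1 in that (2-fluorophenyl in place of 4-chlorophenyl on an aromatic nitrogen). The step that bears most directly on it is a 1.9-fold lower number from compound 1 to compound 3 (0.27 log units; within the scatter), where a halogen likewise moved from the 4-position to the 2-position on the ring attached to the aromatic nitrogen. On that basis, compound 4 is expected to show a step of a 1.5-fold lower number from compound 1 to compound 4 (0.18 log units; within the scatter), not beyond the scatter. The estimate for compound 4 is 270 nM, with a range from 130 nM to 550 nM.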

Compound 4, half-maximal inhibitory concentration: 300 nM
Compound 4: middle estimate off by 1.1-fold (0.05 log units), on the low side; the range from low to high includes it.
By their numbers in this assay, from the lowest: compounds 3, 2, 4 and 1 (each within the scatter of the next).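

On the aromatic nitrogen, 2-fluorophenyl joins the other groups with no step beyond the scatter: a 1.4-fold lower number from compound 1 to compound 4 (0.14 log units; within the scatter), a 1.1-fold higher number from compound 2 to compound 4 (0.05 log units; within the scatter), and a 1.4-fold higher number from compound 3 to compound 4 (0.13 log units; within the scatter). Within the data shown here, that last step is the first to change only the halogen, fluoro in place of chloro on an aromatic carbon, and in this assay it stays within the scatter as well. No evidence is available to explain these values.

The compounds shown leave open whether an amine, a carboxylic acid or a longer chain on the phenyl ring would give a step beyond the scatter. They also leave open how 4-fluorophenyl would compare with 2-fluorophenyl.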